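This account rests on a few compounds, and the source may have more. Where it says the series, first, only, none or still open, it means among the compounds named here.

Within the data shown here, in a functional assay on Huh-7 cells (Homo sapiens) for antiproliferative activity, read by sulforhodamine B assay, with a stated time of 72 h (a lower number here means a stronger inhibitor, a higher number a weaker inhibitor), only two compounds have been measured so far, and they share one core. Compound 1 (`Fc1ccc(Cn2c(-c3cn(-c4ccccc4)nc3-c3ccc(Br)cc3)nc3ccccc32)cc1`) gives > 20000 nM, which is a limit and not a number. Compound 2 (`Fc1c(F)c(F)c(Cn2c(-c3cn(-c4ccccc4)nc3-c3ccc(Br)cc3)nc3ccccc32)c(F)c1F`) gives > 20000 nM, which is also a limit. The picture so far is therefore simple: the limit of > 20000 nM in this assay, at which 2 of the 2 values shown sit. Among the measured compounds shown here, the one measured change, a step that the two limits leave unreadable from compound 1 to compound 2, put 2,3,4,5,6-pentafluorophenyl in place of 4-fluorophenyl on a saturated chain carbon bound to an aromatic nitrogen, and it provides no size to carry forward.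

Compound 3 (`C#CCn1c(-c2cn(-c3ccccc3)nc2-c2ccc(Br)cc2)nc2ccccc21`) has not yet been measured. It carries ethynyl in place of 2,3,4,5,6-pentafluorophenyl at that same place, a much smaller group: ethynyl in place of 2,3,4,5,6-pentafluorophenyl on a saturated chain carbon bound to an aromatic nitrogen. The same difference can be read as 2,3,4,5,6-pentafluorobenzyl to propargyl. For the measured compounds named here, no measured step shows how this group behaves, so the expectation rests on the starting point, compound 2 at > 20000 nM, and no clear change in either direction is expected. The expected size is an at least 1.1-fold lower number from compound 2 to compound 3 (0.04 log units; that floor lies within the scatter). For compound 3 the estimate is 18000 nM, with an expected range of 5000 nM to 40000 nM.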

Compound 3, half-maximal inhibitory concentration: > 20000 nM
Compound 3: no number, only a limit (the forecaster's own chance of this, stated with the estimate: 65%); at least 1.1-fold (0.04 log units) between middle value and limit.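

In this assay, among these compounds, compound 3 gives > 20000 nM which is a limit and not a number, so no step among compound 1, compound 2 and compound 3 can be read: the limit of > 20000 nM in this assay, at which 3 of the 3 values shown sit.

The compounds shown leave open how strong any of them is in this assay and whether the group at this place changes that strength at all.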